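Swapping 4-methoxyphenyl for 3-fluorophenyl on the shared core

The compounds below may be only part of what the source reports. "The series", "measured", "known", "first", "only" and "open" are said of these compounds alone.

Among the measured compounds shown here, in a functional assay on KB cells (Homo sapiens) for inhibition, with a stated time of 72 h (on this read-out lower numbers stand for stronger inhibition and higher numbers for weaker inhibition), compound 3 (`COc1ccc(-c2cccc3c2N(S(=O)(=O)c2ccc(OC)cc2)CC3)cc1`) gives 337 nM as the highest of the three numbers so far. Compound 2 (`COc1ccc(S(=O)(=O)N2CCc3cccc(-c4ccc(F)cc4)c32)cc1`) gives 86 nM and compound 1 (`COc1ccc(S(=O)(=O)N2CCc3cccc(-c4ccc(F)c(F)c4)c32)cc1`) gives 45 nM with a gap inside the scatter (a 1.9-fold higher number from compound 1 to compound 2 (0.28 log units; within the scatter)). Compound 4 (`COc1ccc(S(=O)(=O)N2CCc3cccc(-c4cccc(F)c4)c32)cc1`) has 3-fluorophenyl in place of 4-methoxyphenyl on an aromatic carbon. For the measured compounds named here, two measured steps bear on this change, since compound 1 and compound 2 both carry fluoro on that phenyl group while compound 3 carries methoxy. These steps are modest but beyond the scatter (a 3.9-fold higher number from compound 2 to compound 3 (0.59 log units; beyond the scatter) and a 7.5-fold higher number from compound 1 to compound 3 (0.87 log units; beyond the scatter)). Going by the values given here, no compound measured so far carries the 3-fluorophenyl group itself, so the comparison is indirect. Reversing those steps points to a lower number of similar size in this assay. The expected change for compound 4 is a modest one (a 4.5-fold lower number from compound 3 to compound 4 (0.65 log units; beyond the scatter)). Compound 4 is estimated at 75 nM with an expected range from 30 nM to 190 nM.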

Compound 4, half-maximal inhibitory concentration: 98.5 nM
Beside the measured number, compound 4's estimate is 1.3-fold (0.12 log units) below it; the measured number falls inside the stated range.
By their numbers in this assay, from the lowest: compounds 1, 2 and 4 (each within the scatter of the next, the first and the last beyond it); then compound 3.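

In this assay, the 3-fluorophenyl group also reads lower than 4-methoxyphenyl (a 3.4-fold lower number from compound 3 to compound 4 (0.53 log units; beyond the scatter)), so the advantage over methoxy seen with the earlier fluoro compounds holds for a fluoro group placed differently on the phenyl ring. Moving the single fluoro from the 4-fluorophenyl to the 3-fluorophenyl arrangement does not separate the two compounds (a 1.1-fold higher number from compound 2 to compound 4 (0.06 log units; within the scatter)), whereas the step from 3,4-difluorophenyl to 3-fluorophenyl is modest but beyond the scatter (a 2.2-fold higher number from compound 1 to compound 4 (0.34 log units; beyond the scatter)). Nothing available explains these differences.

As far as these compounds go, it remains open whether a 3-methoxyphenyl group would track 4-methoxyphenyl or 3-fluorophenyl, which would show whether the methoxy group or its place drives the higher number. From the compounds shown here alone, how an unsubstituted phenyl, an aminophenyl or a carboxylic acid on the phenyl ring would read at this position also remains open.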